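This account rests on a few compounds, and the source may have more. Where it says the series, first, only, none or still open, it means among the compounds named here.

Compound 3 `CC#CCn1c(N2CCC[C@@H](N)C2)nc2c1c(=O)n(CCCN1CCN(c3nc(-c4ccccc4)ns3)CC1)c(=O)n2C` gives 1930 nM in a functional assay on HEK293 cells for agonist activity at Glucose-dependent insulinotropic receptor (Homo sapiens), read by a luciferase reporter (on this read-out higher numbers stand for an effect only at larger amounts of compound and lower numbers for an effect already at smaller amounts), the second highest of the three numbers in hand; compound 1 `CC#CCn1c(N2CCC[C@@H](N)C2)nc2c1c(=O)n(CCCN1CCN(c3noc(-c4ccccc4)n3)CC1)c(=O)n2C` gives 1450 nM and compound 2 `CC#CCn1c(N2CCC[C@@H](N)C2)nc2c1c(=O)n(CCCN1CCN(c3ncc(OC)cn3)CC1)c(=O)n2C` gives 2260 nM. Compound 4 `CC#CCn1c(N2CCC[C@@H](N)C2)nc2c1c(=O)n(CCCN1CCN(c3ncc(F)cn3)CC1)c(=O)n2C` carries 5-fluoropyrimidin-2-yl in place of 3-phenyl-1,2,4-thiadiazol-5-yl on an amine nitrogen in a ring. Within the data shown here, two measured steps bear on an exchange of this kind at the same ring nitrogen: a 1.2-fold lower number from compound 2 to compound 3 (0.07 log units; within the scatter) and a 1.6-fold higher number from compound 1 to compound 2 (0.19 log units; within the scatter), both within the scatter, so replacing 5-phenyl-1,2,4-oxadiazol-3-yl or 3-phenyl-1,2,4-thiadiazol-5-yl with a pyrimidinyl has not moved this assay. Among the measured compounds shown here, no measured pair separates 5-fluoropyrimidin-2-yl from 5-methoxypyrimidin-2-yl. The expectation for compound 4 in this assay is therefore no step beyond the scatter, a 1.1-fold higher number from compound 3 to compound 4 (0.04 log units; within the scatter). Compound 4 is estimated at 2100 nM, with a range from 1000 nM to 4500 nM.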

Compound 4, half-maximal effective concentration: 1410 nM
Estimate against measurement, compound 4: 1.5-fold (0.17 log units) above; measured number inside the range.
By their numbers in this assay, from the lowest: compounds 4, 1, 3 and 2 (each within the scatter of the next).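

In this assay, the first pair differing only in the pyrimidine substituent gives a 1.6-fold lower number from compound 2 to compound 4 (0.20 log units; within the scatter), so fluoro in place of methoxy on an aromatic carbon does not separate these two compounds. Losing the phenyl-bearing five-membered rings also leaves the number within the scatter, with a 1.4-fold lower number from compound 3 to compound 4 (0.14 log units; within the scatter) and a 1.0-fold lower number from compound 1 to compound 4 (0.01 log units; within the scatter). No supporting data are available to explain this flat response.

All four compounds carry an aromatic ring on this amine nitrogen. On these data alone, whether an open-chain amine or a carboxylic acid there would move the number beyond the scatter remains open.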